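The source may report more compounds than this note shows. Statements on the series, on what has been measured and on what is new or still open speak of the compounds shown alone.

- compound 1 `C=CCc1ccc(OCc2cn(-c3cccc(C#N)c3)nn2)c(O)c1`: 21.2%
- compound 2 `C=CCc1ccc(OCc2cn(-c3ccc(C(=O)c4ccccc4)cc3)nn2)c(O)c1`: 41.9%

In a functional assay on SK-N-SH cells (Homo sapiens) for inhibition, read by MTT assay, with a stated time of 72 h, tested at 30 uM (on this read-out higher numbers stand for more inhibition of growth at the one concentration tested and lower numbers for less inhibition of growth), compound 2 stands highest of the two at 41.9%, beyond the scatter from compound 1. Compound 3 `C=CCc1ccc(OCc2cn(-c3ccc(Br)cc3)nn2)c(O)c1` has bromo in place of benzoyl on an aromatic carbon, para to a large group: bromo in place of benzoyl on an aromatic carbon. Among the measured compounds shown here, no single-place step has been measured, and the only guide is compound 1, which also lacks the benzoyl and gives 21.2%. A fall in this assay is therefore expected, with the estimated step of a number 11.9 percentage points lower from compound 2 to compound 3 (beyond the scatter) lying near the edge of the scatter. The estimate for compound 3 is 30%, with an expected range of 15% to 47%.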

Compound 3, percent growth inhibition at one concentration: 38.3%
For compound 3 the middle estimate is 8.3 percentage points below the measured one; the measured number falls inside the stated range.
By their numbers in this assay, from the lowest: compound 1; then compounds 3 and 2 (each within the scatter of the next).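

In this assay, bromo in place of benzoyl on this aromatic carbon gives a number 3.6 percentage points lower from compound 2 to compound 3 (within the scatter), so the benzoyl, with its ring and carbonyl, is not required for this level of growth inhibition. With 4-bromophenyl in place of 3-cyanophenyl on the aromatic nitrogen, the change is a number 17.1 percentage points higher from compound 1 to compound 3 (beyond the scatter), so the aryl group on that nitrogen does affect the read-out. No measured property bears on either step.

The 3-cyanophenyl and 4-bromophenyl groups differ in both substituent and ring position, leaving the two contributions unseparated. Going by these compounds, whether an amine or a carboxylic acid on the same aromatic carbon would retain this level also remains open.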